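Working notes: from compound 1 to compound 3

The source may report more compounds than this note shows. Statements on the series, on what has been measured and on what is new or still open speak of the compounds shown alone.

Measured so far in a functional assay on U-251 cells (Homo sapiens) for inhibition, read by MTT assay, with a stated time of 48 h; on this read-out higher numbers stand for weaker inhibition and lower numbers for stronger inhibition:
- compound 1 `C#CCN(C)CCCOc1cc(NCc2ccc(/C=C/C(=O)NO)cc2)ccc1Cl`: 3240 nM
- compound 2 `C#CCN(C)CCCOc1cc(NC(=O)CCCCCCC(=O)NO)c(Cl)cc1Cl`: 50600 nM

Compound 1 holds the lower number of the two, and compound 2 lies above it, beyond the scatter. Compound 3 `C#CCN(C)CCCOc1cc(NCc2ccc(C(=O)NO)cc2)ccc1Cl` has hydroxycarbamoyl in place of 2-(hydroxycarbamoyl)ethenyl on an aromatic carbon, para to a large group (hydroxycarbamoyl in place of 2-(hydroxycarbamoyl)ethenyl on an aromatic carbon). Going by the values given here, no measured pair isolates this change, so the expectation rests on the structural change alone. In this assay a modest rise in the number is expected, a step that may only just clear the scatter. The expected step is a 2.0-fold higher number from compound 1 to compound 3 (0.30 log units; within the scatter). The estimated value for compound 3 is 6500 nM, with an expected range from 2000 nM to 22000 nM.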

Compound 3, half-maximal inhibitory concentration: 10100 nM
Beside the measured number, compound 3's estimate is 1.6-fold (0.19 log units) below it; measured number inside the range.
By their numbers in this assay, from the lowest: compound 1; then compound 3; then compound 2.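

In this assay, going by these compounds alone, replacing 2-(hydroxycarbamoyl)ethenyl with hydroxycarbamoyl on the aromatic carbon, para to a large group, gives a 3.1-fold higher number from compound 1 to compound 3 (0.49 log units; beyond the scatter) and provides the first single-place comparison. This position therefore responds to the change, with compound 1 keeping the lower number of the pair. Nothing on hand accounts for the step.

Still open, from the compounds shown here alone, is whether a longer chain ending in hydroxycarbamoyl, or a carboxylic acid in place of hydroxycarbamoyl, would move the number at this position.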